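This account rests on a few compounds, and the source may have more. Where it says the series, first, only, none or still open, it means among the compounds named here.

Compound 1 `Nc1[nH]c(C(=O)c2ccccc2)c(-c2cccc3ccccc23)c1C(=O)c1ccc(Cl)c(Cl)c1` — an assay for inhibition of Polyunsaturated fatty acid lipoxygenase ALOX15 (Homo sapiens), with a stated time of 10 min; a higher number here means a weaker inhibitor, a lower number a stronger inhibitor: > 100000 nM
Compound 2 `Nc1[nH]c(C(=O)c2ccccc2)c(-c2cccc(Cl)c2)c1C(=O)c1cccc(Cl)c1`: > 100000 nM
Compound 3 `Nc1[nH]c(C(=O)c2ccccc2)c(-c2ccccc2Cl)c1C(=O)c1cccc(Cl)c1`: > 100000 nM

Compound 1 stands at the limit of the assay: its value in this assay is a limit and not a number. Compound 2 is likewise reported only as a limit. Compound 3 too is given only as a limit. Nothing in these numbers separates compound 1 from the other two. Within the data shown here, the single measured change between two compounds, a step that the two limits leave unreadable from compound 2 to compound 3, cannot be read in size because the limit of > 100000 nM in this assay, at which 3 of the 3 values shown sit, covers both ends of it.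

Compound 4 `Nc1[nH]c(C(=O)c2ccccc2)c(-c2ccc(Cl)cc2Cl)c1C(=O)c1ccc(Cl)c(Cl)c1` differs from compound 1 in one place: 2,4-dichlorophenyl in place of naphthalen-1-yl on an aromatic carbon. Among the measured compounds shown here, no measured step bears directly on this change, and none of the measured steps gives a readable size, so there is no ground to expect a step beyond the scatter in this assay in either direction, nor a readable step at all. Compound 4 is therefore expected to sit at the limit as well, with an estimated value of 150000 nM and a range from 30000 nM to 1000000 nM. The expected step is a step that the limit leaves unreadable from compound 1 to compound 4.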

Compound 4, half-maximal inhibitory concentration: 12800 nM
Beside the measured number, compound 4's estimate is 12-fold (1.07 log units) above it; measured number outside the range, below it.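

In this assay, the group on the aromatic carbon two ring bonds from the ring nitrogen proves able to shift the read-out: 2,4-dichlorophenyl in place of naphthalen-1-yl gives an at least 7.8-fold lower number from compound 1 to compound 4 (0.89 log units; beyond the scatter). Compound 4 is the only compound shown with a value that is a number and not a limit, whereas the one earlier step, between compound 2 and compound 3, cannot be read. The new step has a lower bound and no known full size because compound 1 itself is reported only as a limit: the limit of > 100000 nM in this assay, at which 3 of the 4 values shown sit.

The change replaces two aromatic rings of carbon with one and brings in two chlorine atoms at once, so the compounds shown do not tell whether the ring count, the chlorine atoms or the particular 2,4-dichlorophenyl pattern accounts for the step. As far as these compounds go, it also remains open how this position would respond to a 4-chlorophenyl group or a methoxy-bearing phenyl group, and whether a carboxylic acid or an amine on the benzoyl group would move the number any further from that of compound 4.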